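Compound 1 to compound 3: methyl to ethyl

This account rests on a few compounds, and the source may have more. Where it says the series, first, only, none or still open, it means among the compounds named here.

In an ADME assay on microsomes from liver (Rattus norvegicus) for metabolic stability, with a stated time of 10 min, tested at 0.5 uM (on this read-out lower numbers stand for a less stable compound and higher numbers for a more stable compound), compound 1 (`Cc1noc(C)c1[C@@H]1C[C@@](C)(c2ccc(F)cc2F)N=C(N)S1`) gives 78% and stands level with compound 2 (`Cc1noc(C)c1[C@@H]1C[C@@](C)(c2ccc(F)cc2)N=C(N)S1`) at 78%. Compound 3 (`CCc1noc(C)c1[C@@H]1C[C@@](C)(c2ccc(F)cc2F)N=C(N)S1`) has not yet been measured. It keeps the core of compound 1 and alters one group, 3,5-dimethyl-1,2-oxazol-4-yl becoming 3-ethyl-5-methyl-1,2-oxazol-4-yl (methyl in place of hydrogen on a saturated chain carbon bound to an aromatic carbon). This is methyl in place of hydrogen on a saturated chain carbon bound to an aromatic carbon.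

Among the measured compounds shown here, the only measured step is hydrogen in place of fluoro on an aromatic carbon (no change at the digits printed from compound 1 to compound 2 (within the scatter)), and it lies within the scatter. It sits at another place in the structure, so it bears on the new change only indirectly. For the measured compounds named here, no measured step covers methyl to ethyl, and the data do not fix a direction for it. A small step with a slight downward lean is therefore expected (a number 6 percentage points lower from compound 1 to compound 3 (within the scatter)), and it may not clear the scatter. For compound 3 the estimated value is 72%, with an expected range from 58% to 84%.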

Compound 3, percent of the compound remaining: 59%
Compound 3: the middle estimate sits 13 percentage points above what was measured, within the range that was stated.
By their numbers in this assay, from the lowest: compound 3; then compounds 1 and 2 (each within the scatter of the next).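

Extending 3,5-dimethyl-1,2-oxazol-4-yl to 3-ethyl-5-methyl-1,2-oxazol-4-yl, which places methyl in place of hydrogen on a saturated chain carbon bound to an aromatic carbon, gives in this assay a number 19 percentage points lower from compound 1 to compound 3 (beyond the scatter), the only step shown that clears the scatter. This position therefore responds to the addition of a single methyl, whereas hydrogen in place of fluoro on an aromatic carbon, at another place in the structure, gave no change at the digits printed from compound 1 to compound 2 (within the scatter) and so showed no such sensitivity. No measurement available here accounts for the lower number, so the step stands as an observation only.

The compounds shown leave open whether the number keeps falling with a longer chain such as propyl at this place, or whether a branched isopropyl or a methoxymethyl group would read differently from ethyl. They also leave open whether the same methyl to ethyl change would have a similar size on the core of compound 2, or with the 5-methyl group changed in place of the other methyl.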